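Replacing a biaryl group with a methoxystyryl group in a bile acid receptor series

This account rests on a few compounds, and the source may have more. Where it says the series, first, only, none or still open, it means among the compounds named here.

Measured compounds:
compound 1, `COC(=O)/C=C/c1cccc(N(Cc2ccc(/C=C/c3scnc3C)cc2)C(=O)C(C)C)c1`, 228 nM
compound 2, `COC(=O)/C=C/c1cccc(N(Cc2ccc(-c3c(OC)cccc3OC)cc2)C(=O)C2CCCCC2)c1`, 77 nM
compound 3, `COC(=O)/C=C/c1cccc(N(Cc2ccc(-c3c(OC)cccc3OC)cc2)C(=O)C(C)C)c1`, 95 nM

In an assay on isolated protein with Bile acid receptor (Homo sapiens) as the target (on this read-out higher numbers stand for an effect only at larger amounts of compound and lower numbers for an effect already at smaller amounts), compound 2 gives the lowest of the three numbers, with compound 3 nearest, a 1.2-fold higher number from compound 2 to compound 3 (0.09 log units; within the scatter), a step that stays within the scatter and therefore allows no ranking of these two. For the measured compounds named here, compound 1 lies furthest from compound 2, and its value is reached through compound 3 by the step of a 2.4-fold lower number from compound 1 to compound 3 (0.38 log units; beyond the scatter), which is the only change at the same aromatic carbon that has been measured.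

The unmeasured compound 4 is `COC(=O)/C=C/c1cccc(N(Cc2ccc(/C=C/c3ccc(OC)cc3)cc2)C(=O)C2CCCCC2)c1`. It differs from compound 2 in one place: 2-(4-methoxyphenyl)ethenyl in place of 2,6-dimethoxyphenyl on an aromatic carbon. This step partly undoes the change seen between compound 1 and compound 3, since it again puts a 2-(aryl)ethenyl group where the 2,6-dimethoxyphenyl group stood in compound 2 and compound 3. As that earlier change lowered the number by a modest, beyond-the-scatter amount, the account expects the reverse direction here: a modestly higher number in this assay, though the 4-methoxyphenyl and 4-methyl-1,3-thiazol-5-yl groups are not the same, so the size is uncertain.

Compound 4 is therefore estimated at 150 nM, with a range of 70 nM to 350 nM, an expected step of a 1.9-fold higher number from compound 2 to compound 4 (0.29 log units; within the scatter).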

Compound 4, half-maximal effective concentration: 208 nM
For compound 4 the middle estimate is 1.4-fold (0.14 log units) below the measured one; the range from low to high includes it.
By their numbers in this assay, from the lowest: compounds 2 and 3 (each within the scatter of the next); then compounds 4 and 1 (each within the scatter of the next).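

In this assay, the aromatic carbon para to a large group responds to this exchange even with the cyclohexyl carbonyl in place, with a 2.7-fold higher number from compound 2 to compound 4 (0.43 log units; beyond the scatter). Until now, a 2-(aryl)ethenyl group and the 2,6-dimethoxyphenyl group had been compared only on the isopropyl carbonyl, with a thiazole-bearing group, in a 2.4-fold lower number from compound 1 to compound 3 (0.38 log units; beyond the scatter); across these two pairs, the compound with 2,6-dimethoxyphenyl has the lower number, and no pair shown goes against this. The step also shows that an equal count of 10 heavy atoms in the leaving and entering groups does not keep the number in place, although the entering group has one hydrogen-bond acceptor fewer and a double bond outside the aromatic ring. Nothing available explains the step.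

The compounds shown do not separate the ethenyl link from the change in methoxy substitution, a question that a 4-methoxyphenyl group attached directly to the aromatic carbon would address. They also leave open how a carboxylic acid in place of the methyl ester would read in this assay.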